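From nitro to fluoro on compound 3

The compounds below may be only part of what the source reports. "The series", "measured", "known", "first", "only" and "open" are said of these compounds alone.

In a functional assay on T47D cells (Homo sapiens) for cytotoxicity, read by MTT assay, with a stated time of 96 h (a higher number here means a weaker inhibitor, a lower number a stronger inhibitor), compound 3 (`N=C(N)c1ccc(-c2ccc(-c3cccc([N+](=O)[O-])c3)o2)cc1`) gives 3300 nM. Compound 1 (`CCc1ccc(-c2ccc(-c3ccc(C(=N)N)cc3)o2)cc1`) gives 3000 nM and compound 2 (`Cn1c(-c2ccccc2)ccc1-c1ccc(C(=N)N)cc1`) gives 2100 nM, so compound 3 stands within the scatter of both. Compound 4 (`N=C(N)c1ccc(-c2ccc(-c3cccc(F)c3)o2)cc1`) has not yet been measured. It differs from compound 3 as follows: fluoro in place of nitro on an aromatic carbon, meta to a large group. For the measured compounds named here, no measured pair shows this change directly, so the only guide is the narrow spread of the three values, and no step beyond the scatter is expected. The expected change is a 1.1-fold lower number from compound 3 to compound 4 (0.04 log units; within the scatter). For compound 4 the estimate is 3000 nM, with an estimated range of 1300 nM to 6500 nM.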

Compound 4, half-maximal inhibitory concentration: 2800 nM
Compound 4: the middle estimate sits 1.1-fold (0.03 log units) above what was measured; the range from low to high includes it.
By their numbers in this assay, from the lowest: compounds 2, 4, 1 and 3 (each within the scatter of the next).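

In this assay, fluoro in place of nitro on an aromatic carbon, meta to a large group, gives a 1.2-fold lower number from compound 3 to compound 4 (0.07 log units; within the scatter), so this position tolerates the exchange with no step beyond the scatter. Nitro carries nitrogen, oxygen and hydrogen-bond acceptors that fluoro lacks, yet this read-out does not tell the two compounds apart. No measured evidence offers an explanation for this result. From the compounds shown here alone, whether an amine or a carboxylic acid on this carbon would also stay within the scatter remains open. So does whether fluoro would behave alike elsewhere on the ring.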